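The source may report more compounds than this note shows. Statements on the series, on what has been measured and on what is new or still open speak of the compounds shown alone.

Of the compounds shown here, three have been tested in a functional assay on the whole organism for inhibition, with Rattus norvegicus as the target, read by paw edema, with stated times of 4 days, 1 h and 2 h, at a dose of 100 mg/kg by the oral route; a higher number here means more inhibition at the dose given (going by the name of the read-out), a lower number less inhibition. Compound 1 `Ic1ccc2nc(-c3ccccc3)nc(N3CCC(c4ccccc4)CC3)c2c1` gives 82.5% in this assay. Compound 2 `Clc1ccc(-c2nc(N3CCC(c4ccccc4)CC3)c3ccccc3n2)cc1` gives 53.7% in this assay, and compound 3 `CC1CCN(c2nc(-c3ccc(Cl)cc3)nc3ccc(I)cc23)CC1` gives 45.8% in this assay. Compound 3 and compound 2 sit together at the lower end of the range, their gap within the usual scatter, while compound 1 stands beyond the scatter above both.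

Compound 4 `Clc1ccc(-c2nc(N3CCC(c4ccccc4)CC3)c3cc(I)ccc3n2)cc1` has not yet been measured in this assay. It differs from compound 3 in one place (phenyl in place of methyl on a saturated ring carbon). Compound 4 thereby carries the same saturated-ring substituent as compound 2 and compound 1, together with the iodine of compound 3 and compound 1 and the chlorophenyl group of compound 2 and compound 3.

Because compound 2 gives 53.7% with that phenyl on the saturated ring, compound 4 is expected to lie near it or somewhat higher, an expected step of a number 14.2 percentage points higher from compound 3 to compound 4 (beyond the scatter) of modest size upward, possibly no more than the scatter. The estimate for compound 4 is 60%, within 42% to 78%.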

Compound 4, a percentage reported as inhibition, in the whole organism at one dose (the size of the read-out at that dose, not a potency): 41.4%
The estimate for compound 4 lay 18.6 percentage points above the measured number, outside the stated range (below it).
By their numbers in this assay, from the lowest: compounds 4, 3 and 2 (each within the scatter of the next, the first and the last beyond it); then compound 1.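

In this assay, phenyl in place of methyl on a saturated ring carbon gives a number 4.4 percentage points lower from compound 3 to compound 4 (within the scatter), so with the iodine and the chlorophenyl group both present, this position shows no readable difference between the two groups. The changes on the aromatic carbons do register: iodo in place of hydrogen gives a number 12.3 percentage points lower from compound 2 to compound 4 (beyond the scatter), and chloro in place of hydrogen gives a number 41.1 percentage points lower from compound 1 to compound 4 (beyond the scatter), a large step that sets this change well apart from the swap on the saturated ring. Nothing measured here explains these numbers.

On these data alone, whether an amine or a carboxylic acid on that saturated ring carbon would read any differently from phenyl or methyl remains open. So does whether a methoxy group or a fluorine in place of the chloro would give a step of similar size.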